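This account rests on a few compounds, and the source may have more. Where it says the series, first, only, none or still open, it means among the compounds named here.

Compound 1: `C[C@@H](Cc1ccc2ocnc2c1)CN1C[C@@H]2CCCC[C@@H]2[C@H](C(=O)N2CCN(c3ccc(F)c(F)c3)CC2)C1` — 11 nM
Compound 2: `C[C@@H](Cc1ccc2nccnc2c1)CN1C[C@@H]2CCCC[C@@H]2[C@H](C(=O)N2CCN(c3ccc(F)c(F)c3)CC2)C1` — 10.7 nM

Both compounds were tested in an assay on isolated protein for binding affinity to somatostatin receptor type 3 (Homo sapiens); on this read-out higher numbers stand for weaker binding and lower numbers for tighter binding. Compound 1 gives 11 nM, and compound 2 gives 10.7 nM. Going by the values given here, the single measured step, a 1.0-fold lower number from compound 1 to compound 2 (0.01 log units; within the scatter), shows that exchanging one two-ring aromatic group for another at this position left the binding unchanged. Compound 2 therefore holds the lowest of the two numbers, but its step to compound 1 lies within the scatter, so the two compounds cannot be told apart on these data.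

Compound 3 is `CCNc1ccc(C[C@H](C)CN2C[C@@H]3CCCC[C@@H]3[C@H](C(=O)N3CCN(c4ccc(F)c(F)c4)CC3)C2)cn1`. It differs from compound 2 by 6-(ethylamino)pyridin-3-yl in place of quinoxalin-6-yl on a saturated chain carbon, three bonds along the chain from an amine nitrogen in a ring. Among the compounds with values here, the one measured step concerns the same position on the shared core, yet it swapped one two-ring group for another, whereas here a single six-membered ring carrying an ethylamino group enters. Within the data shown here, no measured step covers a change of that kind, so the expectation rests on the indifference seen so far. A small step, if any, is expected: a 1.4-fold higher number from compound 2 to compound 3 (0.15 log units; within the scatter). For compound 3 in this assay the estimate is 15 nM, with a range from 4 nM to 60 nM.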

Compound 3, dissociation constant: 28.8 nM
The estimate for compound 3 lay 1.9-fold (0.28 log units) below the measured number; measured number inside the range.
By their numbers in this assay, from the lowest: compounds 2 and 1 (each within the scatter of the next); then compound 3.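

In this assay, this position turns out not to be indifferent to every aromatic group: there is a 2.7-fold higher number from compound 2 to compound 3 (0.43 log units; beyond the scatter), and likewise a 2.6-fold higher number from compound 1 to compound 3 (0.42 log units; beyond the scatter), both modest but beyond the scatter. Going by these compounds alone, the earlier pair showed only that one two-ring group could replace another with no readable change, whereas replacing either with 6-(ethylamino)pyridin-3-yl, a single six-membered ring that brings a hydrogen-bond donor, gives weaker binding. Nothing measured here gives a reason for this loss of binding.

The change from two rings to one and the arrival of the ethylamino group happen together, so the compounds shown leave open which of the two goes with the higher number. A bare pyridin-3-yl group, or an ethoxy group in place of the ethylamino group with the rest of compound 3 kept, would help pull these two parts of the change apart.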